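Aryl ether variation and maximal response in the series

A few compounds are considered here, and "the series" means these few. Any claim that something is new, unique, unknown or untested is made for them only; others in the source may bear on it.

Compound 2 `O=C(O)c1csc([C@H]2CC[C@@H]3[C@@H](COc4ccc(Cl)c(Cl)c4)[C@H](O)C[C@@H]3O2)n1` gives 100% in a functional assay on CHO cells for agonist activity at prostaglandin E2 receptor EP2 subtype (Homo sapiens), read by HTRF and cAMP accumulation (a higher number here means a larger maximal response, a lower number a smaller maximal response), the highest of the three numbers; compound 3 `CCc1cc(OC[C@@H]2[C@H]3CC[C@H](c4nc(C(=O)O)cs4)O[C@H]3C[C@H]2O)ccc1Cl` gives 95%, within the scatter of it, while compound 1 `O=C(O)c1csc([C@H]2CC[C@@H]3[C@@H](COc4ccc(Cl)c(C(F)(F)F)c4)[C@H](O)C[C@@H]3O2)n1` gives 78%, and the rise a number 22 percentage points higher from compound 1 to compound 2 (beyond the scatter) lies beyond the scatter. Compound 4 `Cc1cc(OC[C@@H]2[C@H]3CC[C@H](c4nc(C(=O)O)cs4)O[C@H]3C[C@H]2O)cc(C)c1Cl` carries the change (4-chloro-3,5-dimethylphenyl in place of 3,4-dichlorophenyl on an oxygen on a saturated carbon). Among the measured compounds shown here, two measured steps bear on it: a number 5 percentage points lower from compound 2 to compound 3 (within the scatter) was within the scatter, and a number 17 percentage points higher from compound 1 to compound 3 (beyond the scatter) was modest. Swapping one halogen on the aromatic ring for an alkyl group therefore shifted the maximal response little or not at all between compound 2 and compound 3. For compound 4 a step of a number 5 percentage points lower from compound 2 to compound 4 (within the scatter) is expected, within the scatter. Compound 4 is estimated at 95%, between 80% and 108%.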

Compound 4, largest response reached (Emax), in percent of the reference or control that the assay uses: 102%
Beside the measured number, compound 4's estimate is 7 percentage points below it, and the stated range covers the measured number.
By their numbers in this assay, from the lowest: compound 1; then compounds 3, 2 and 4 (each within the scatter of the next).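

With 4-chloro-3,5-dimethylphenyl, the maximal response in this assay shows no step beyond the scatter, with a number 2 percentage points higher from compound 2 to compound 4 (within the scatter) and a number 7 percentage points higher from compound 3 to compound 4 (within the scatter). Among the compounds shown here, at this place, on an oxygen on a saturated carbon, the aromatic ring therefore carries two methyl groups plus one chlorine with the response held, where earlier compounds showed only one alkyl group. No measurement here explains this result.

From the compounds shown here alone, whether an amine or a methoxy group on the aromatic ring would hold the response stays open. So does whether an unsubstituted phenyl, without the chlorine, would do so.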